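Chlorophenyl in Place of Phenylethenyl on the Shared Core

The compounds below may be only part of what the source reports. "The series", "measured", "known", "first", "only" and "open" are said of these compounds alone.

Of the compounds shown here, three built on a shared core have been tested in a functional assay on the whole organism for inhibition, with Mus musculus as the target, in the writhing test, with a stated time of 15 min, at a dose of 10 mg/kg; on this read-out higher numbers stand for more inhibition at the one dose given (going by the name of the read-out) and lower numbers for less inhibition. Compound 1 `COc1ccc(C2CC(C3C(=O)c4ccccc4C3=O)=NC(=O)N2)cc1` gives 31%, compound 2 `O=C1N=C(C2C(=O)c3ccccc3C2=O)CC(c2ccc([N+](=O)[O-])cc2)N1` gives 38%, and compound 3 `O=C1N=C(C2C(=O)c3ccccc3C2=O)CC(/C=C/c2ccccc2)N1` gives 16%, the lowest of the three numbers, its nearest neighbour being compound 1 and its furthest compound 2. Within the data shown here, two measured steps bear directly on the change now considered: a number 15 percentage points lower from compound 1 to compound 3 (beyond the scatter), and a number 22 percentage points lower from compound 2 to compound 3 (beyond the scatter). Both times the 2-phenylethenyl group entered on the saturated ring carbon, the inhibition fell beyond the scatter. Compound 4 `O=C1N=C(C2C(=O)c3ccccc3C2=O)CC(c2ccc(Cl)cc2)N1` runs that change the other way: 4-chlorophenyl in place of 2-phenylethenyl on a saturated ring carbon. A substituted phenyl returning to that position is therefore expected to bring the inhibition back up toward the level seen for compound 1 and compound 2. The step from compound 3 is expected to be a number 17 percentage points higher from compound 3 to compound 4 (beyond the scatter). Compound 4 is expected to give 33% in this assay, with a range from 22% to 45%.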

Compound 4, a percentage reported as inhibition, in the whole organism at one dose (the size of the read-out at that dose, not a potency): 44%
Compound 4: middle estimate off by 11 percentage points, on the low side; the range from low to high includes it.
By their numbers in this assay, from the lowest: compound 3; then compounds 1, 2 and 4 (each within the scatter of the next, the first and the last beyond it).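

In this assay the change to 4-chlorophenyl gives a number 28 percentage points higher from compound 3 to compound 4 (beyond the scatter), so all three substituted phenyl groups shown on the saturated ring carbon now stand beyond the scatter above the 2-phenylethenyl group of compound 3. Among these compounds, the substituent on the phenyl ring also begins to matter: chloro in place of methoxy gives a number 13 percentage points higher from compound 1 to compound 4 (beyond the scatter), the first step beyond the scatter between two phenyl substituents, whereas chloro in place of nitro gives a number 6 percentage points higher from compound 2 to compound 4 (within the scatter) and leaves those two groups unordered. Nothing available explains these differences.

The compounds shown leave open how a phenyl without a substituent, or one carrying an amine or a carboxylic acid, would behave at this position. With one dose only, they also cannot show how the compounds compare in potency.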